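This account rests on a few compounds, and the source may have more. Where it says the series, first, only, none or still open, it means among the compounds named here.

- compound 1 `Cc1ccc(C(C)C)c(OCc2cn(-c3ccccc3)nn2)c1` gives 45100 nM
- compound 2 `Cc1ccc(C(C)C)c(OCc2cn(-c3ccc(O)cc3)nn2)c1` gives 30500 nM

For the measured compounds named here, in a functional assay on MDA-MB-231 cells (Homo sapiens) for inhibition, read by MTT assay, with a stated time of 72 h (a lower number here means a stronger inhibitor, a higher number a weaker inhibitor), compound 2 stands within the scatter of compound 1, its only neighbour so far. The move to compound 3 `Cc1ccc(C(C)C)c(OCc2cn(-c3ccccc3Cl)nn2)c1` puts 2-chlorophenyl in place of 4-hydroxyphenyl on an aromatic nitrogen, counted as 2-chlorophenyl in place of 4-hydroxyphenyl on an aromatic nitrogen in full. Going by the values given here, the only measured step bearing on it, a 1.5-fold lower number from compound 1 to compound 2 (0.17 log units; within the scatter) for hydroxy in place of hydrogen on an aromatic carbon, lies within the scatter. Among the compounds with values here, no chlorine-bearing compound has been measured yet, so no step beyond the scatter is expected in this assay in either direction. The expected step is a 1.1-fold lower number from compound 2 to compound 3 (0.04 log units; within the scatter) in size. For compound 3 the estimate is 28000 nM with an expected range from 11000 nM to 70000 nM as a working figure.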

Compound 3, half-maximal inhibitory concentration: 26600 nM
The estimate for compound 3 lay 1.1-fold (0.02 log units) above the measured number; the range from low to high includes it.
By their numbers in this assay, from the lowest: compounds 3, 2 and 1 (each within the scatter of the next).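

In this assay there is a 1.1-fold lower number from compound 2 to compound 3 (0.06 log units; within the scatter) for 2-chlorophenyl in place of 4-hydroxyphenyl on the aromatic nitrogen, and a 1.7-fold lower number from compound 1 to compound 3 (0.23 log units; within the scatter) for the addition of a chlorine to the phenyl on that nitrogen. The group on this nitrogen has now carried a chlorine as well as a hydroxy, and losing the hydrogen-bond donor and acceptor of 4-hydroxyphenyl gives no step beyond the scatter. No measurement at hand explains this result. Still open, on these data alone, is whether an amine or a carboxylic acid on the phenyl, or a longer chain in its place, would give a step beyond the scatter.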